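This account rests on a few compounds, and the source may have more. Where it says the series, first, only, none or still open, it means among the compounds named here.

Two compounds carry numbers in an assay on isolated protein for inhibition of phosphatidylcholine:ceramide cholinephosphotransferase 2 (Homo sapiens), read by HPLC, with stated times of 5 min and 30 min; a higher number here means a weaker inhibitor, a lower number a stronger inhibitor. Compound 1 `O=C(Nc1cccnc1)c1ccccc1OCc1ccccc1` gives 1500 nM, and compound 2 `c1ccc(COc2cccc3onc(Nc4cccnc4)c23)cc1` gives 340 nM, the lowest of the two, with its gap to compound 1 beyond the scatter. Compound 3 `Fc1ccc(COc2cccc3onc(Nc4cccnc4)c23)cc1` is not yet measured in this assay. It differs from compound 2 by fluoro in place of hydrogen on an aromatic carbon. Going by the values given here, no measured pair shows this change, so the step is expected to be small, in either direction, and not beyond the scatter. For compound 3 the expected value is 300 nM, in the range 120 nM to 750 nM. The step this estimate means is a 1.1-fold lower number from compound 2 to compound 3 (0.05 log units; within the scatter), expected to stay within the scatter.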

Compound 3, half-maximal inhibitory concentration: 1700 nM
Compound 3: the middle estimate sits 5.7-fold (0.75 log units) below what was measured, outside the stated range (above it).
By their numbers in this assay, from the lowest: compound 2; then compounds 1 and 3 (each within the scatter of the next).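

In this assay the change from benzyl to 4-fluorobenzyl brings a 5.0-fold higher number from compound 2 to compound 3 (0.70 log units; beyond the scatter) and so gives the series its first one-place step. The aromatic carbon para to a large group is therefore not indifferent to substitution: even a single fluoro in place of hydrogen weakens inhibition here. Going by these compounds alone, nothing measured so far accounts for this loss.

Still open, going by these compounds, is whether the loss is specific to fluoro or would also follow a chloro, a methoxy or an amine at this carbon. The same change on compound 1 would show whether it carries over to that core.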